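This account rests on a few compounds, and the source may have more. Where it says the series, first, only, none or still open, it means among the compounds named here.

Of the compounds shown here, two of a shared core have been measured so far. Compound 1 `CCN(C/C=C/C#CC(C)(C)C)Cc1cccc(OC[Si](C)(C)c2cccc(C)c2)c1` gives 3000 nM in a functional assay on liver (Sus scrofa) for inhibition of squalene monooxygenase (Homo sapiens), using microsomes; on this read-out lower numbers stand for stronger inhibition and higher numbers for weaker inhibition. For the measured compounds named here, compound 2 `CCN(C/C=C/C#CC(C)(C)C)Cc1cccc(OC[Si](C)(C)c2ccc(C=O)cc2)c1` gives 100 nM in this assay, the lowest of the two numbers; the only step known, a 30-fold lower number from compound 1 to compound 2 (1.48 log units; beyond the scatter), was large. Compound 3 `CCN(C/C=C/C#CC(C)(C)C)Cc1cccc(OC[Si](C)(C)c2ccc(C(=O)C(F)(F)F)cc2)c1` differs from compound 2 by trifluoromethyl in place of hydrogen on a carbonyl carbon. Going by the values given here, no measured step alters this carbonyl carbon, so the earlier step gives little guidance; the number for compound 3 is expected to stay near that of compound 2, with a 1.5-fold higher number from compound 2 to compound 3 (0.18 log units; within the scatter) expected. The estimate for compound 3 is 150 nM, within 40 nM to 600 nM.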

Compound 3, half-maximal inhibitory concentration: 5000 nM
Compound 3: the middle estimate sits 33-fold (1.52 log units) below what was measured; measured number outside the range, above it.
By their numbers in this assay, from the lowest: compound 2; then compounds 1 and 3 (each within the scatter of the next).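

In this assay, this carbonyl carbon proves highly sensitive: trifluoromethyl in place of its hydrogen gives a 50-fold higher number from compound 2 to compound 3 (1.70 log units; beyond the scatter), so the low number seen with 4-formylphenyl does not carry over to this closely related group. With a 1.7-fold higher number from compound 1 to compound 3 (0.22 log units; within the scatter), 4-((trifluoromethyl)carbonyl)phenyl and 3-methylphenyl on the silicon cannot be told apart in this measurement. Nothing available explains why the trifluoromethyl group has this effect. On these data alone, it remains open whether a methyl group, an amine or a carboxylic acid at this position would give a number closer to that of compound 2 or of compound 3.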